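Sulfanyl to sulfonyl: the step to compound 4

The compounds below may be only part of what the source reports. "The series", "measured", "known", "first", "only" and "open" are said of these compounds alone.

Measured so far in a functional assay on DU-145 cells (Homo sapiens) for inhibition, read by trypan blue exclusion, with a stated time of 96 h; on this read-out higher numbers stand for weaker inhibition of growth and lower numbers for stronger inhibition of growth:
Compound 1 `CCOc1ccc(/C=C(/SCc2ccc(F)cc2)C(=O)c2ccc(Br)cc2)cc1OC` gives 50000 nM
Compound 2 `CCOc1ccc(/C=C(/Sc2ccc(C)cc2)C(=O)c2ccc(Br)cc2)cc1OC` gives 50000 nM
Compound 3 `CCOc1ccc(/C=C(/Sc2ccc(C)cc2)C(=O)c2ccc(Cl)cc2)cc1OC` gives 25000 nM

On these numbers compound 2 shares its value with compound 1 and stands within the scatter of compound 3. Compound 4 `CCOc1ccc(/C=C(\C(=O)c2ccc(Br)cc2)S(=O)(=O)c2ccc(C)cc2)cc1OC` differs from compound 2 by (4-methylphenyl)sulfonyl in place of (4-methylphenyl)sulfanyl on a double-bonded chain carbon bound to a carbonyl carbon and a double-bonded chain carbon, with (4-methylphenyl)sulfonyl in place of (4-methylphenyl)sulfanyl on a double-bonded chain carbon bound to a carbonyl carbon and a double-bonded chain carbon. The nearest measured steps, no change at the digits printed from compound 1 to compound 2 (within the scatter) and a 2.0-fold lower number from compound 2 to compound 3 (0.30 log units; within the scatter), both stay within the scatter, and neither alters the sulfur itself. No sulfonyl has been measured yet, so the expectation is uncertain. The expected result in this assay is a 1.7-fold lower number from compound 2 to compound 4 (0.22 log units; within the scatter), nothing beyond the scatter. For compound 4 the estimated value is 30000 nM, within an expected range from 6000 nM to 90000 nM.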

Compound 4, concentration for 50% growth inhibition: 1000 nM
Estimate against measurement, compound 4: 30-fold (1.48 log units) above; measured number below the stated range.
By their numbers in this assay, from the lowest: compound 4; then compounds 3, 1 and 2 (each within the scatter of the next).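

In this assay, going by these compounds alone, (4-methylphenyl)sulfonyl in place of (4-methylphenyl)sulfanyl gives a 50-fold lower number from compound 2 to compound 4 (1.70 log units; beyond the scatter) and is the first step here to alter the sulfur itself. The same sulfonyl in place of (4-fluorobenzyl)sulfanyl gives a 50-fold lower number from compound 1 to compound 4 (1.70 log units; beyond the scatter) and also lies beyond the scatter, whereas changing the group on a sulfanyl sulfur stayed within it. Nothing available explains the size of these steps. Going by these compounds, it remains open how a sulfinyl group at this place would compare, and whether chloro in place of bromo would matter on the sulfonyl compound.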